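From amino to methylamino on compound 2

The compounds below may be only part of what the source reports. "The series", "measured", "known", "first", "only" and "open" are said of these compounds alone.

In an ADME assay on a cell-free system (serum) for metabolic stability (on this read-out lower numbers stand for a shorter-lived compound and higher numbers for a longer-lived compound), compound 1 `CC(C)(C)c1cc(OC(=O)c2ccc(N)cc2)ccc1O` gives < 0.25 h, and this is a limit of the assay, not a number. Compound 2 `CC(C)(C)c1cc(NC(=O)c2c(Cl)cc(N)cc2Cl)ccc1O` gives > 1 h, and this too is only a limit. For the measured compounds named here, the two limits place compound 2 on the longer-lived side of the pair, but neither gives an exact half-life, and no single-place step links the two compounds.

Compound 3 `CNc1cc(Cl)c(C(=O)Nc2ccc(O)c(C(C)(C)C)c2)c(Cl)c1` is the next case: methyl in place of hydrogen on a nitrogen on an aromatic ring, with methyl in place of hydrogen on a nitrogen on an aromatic ring, that is, amino to methylamino. Going by the values given here, no measured step in this assay covers this change, so the expectation rests only on compound 2 and its limit of > 1 h. No shift beyond the usual scatter is expected, and the estimated step that the limit leaves unreadable from compound 2 to compound 3 should be read with that limit in mind. Compound 3 is likely to be reported only as a limit as well. The estimated half-life of compound 3 is 1.5 h, with an expected range of 0.7 h to 4 h.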

Compound 3, half-life: > 1 h
Compound 3 gave a limit, no number (the forecaster's own chance of this, stated with the estimate: 70%); the middle value does not contradict the limit.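

In this assay compound 3 gives > 1 h, which is a limit, not a number. For the compounds shown here, compound 2 also stands at a limit, and no step from amino to methylamino can be read between compound 2 and compound 3. The compounds shown leave open whether this change shifts the half-life at all, and in which direction.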